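Aryl Halogen Exchange at a Ring Amine Nitrogen

A few compounds are considered here, and "the series" means these few. Any claim that something is new, unique, unknown or untested is made for them only; others in the source may bear on it.

Compound 1 `CCCn1c(=O)[nH]c2nc(-c3ccc(S(=O)(=O)N4CCN(C)CC4)cc3)[nH]c2c1=O`: > 1000 nM
Compound 2 `CCCn1c(=O)[nH]c2nc(-c3ccc(S(=O)(=O)N4CCN(c5cccc(Br)c5)CC4)cc3)[nH]c2c1=O`: > 1000 nM

In an assay on CHO cells for displacement of a labelled ligand from adenosine receptor A3 (Homo sapiens), read by scintillation counting, with a stated time of 45 min, in the presence of a further agent that is not named here (on this read-out higher numbers stand for weaker inhibition and lower numbers for stronger inhibition), compound 1 gives > 1000 nM, which is a limit of the assay and not a number. Compound 2 gives > 1000 nM in this assay, again a limit. The step that the two limits leave unreadable from compound 1 to compound 2 therefore cannot be read in size or direction. Compound 2 thus stands at the limit of > 1000 nM in this assay, at which 2 of the 2 values shown sit, with no number of its own in this assay.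

Compound 3 `CCCn1c(=O)[nH]c2nc(-c3ccc(S(=O)(=O)N4CCN(c5ccc(I)cc5)CC4)cc3)[nH]c2c1=O` differs from compound 2 by 4-iodophenyl in place of 3-bromophenyl on an amine nitrogen in a ring. For the measured compounds named here, the only measured step that touches this position, a step that the two limits leave unreadable from compound 1 to compound 2, is unreadable, so it gives no basis for expecting a change beyond the scatter in either direction. Compound 3 is therefore expected to stand where compound 2 stands, with an expected step that the limit leaves unreadable from compound 2 to compound 3. Compound 3 is estimated at 3000 nM in this assay, within a range from 800 nM to 15000 nM.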

Compound 3, inhibition constant: > 1000 nM
Compound 3: no number, only a limit (the forecaster's own chance of this, stated with the estimate: 80%); the middle value lies beyond the limit too.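

In this assay compound 3 gives > 1000 nM, again a limit and not a number. The steps linking compound 3 to compound 1 and compound 2 cannot be read. The compounds shown leave open whether methyl, 3-bromophenyl or 4-iodophenyl on the amine nitrogen in the ring changes inhibition at all.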